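Extending the chain on a urea-based acyltransferase inhibitor

This account rests on a few compounds, and the source may have more. Where it says the series, first, only, none or still open, it means among the compounds named here.

Three compounds share one core and differ only in a chain on the outer aromatic ring. Compound 1 `CCCc1ccc(NC(=O)Nc2c(C(C)C)cccc2C(C)C)cc1` gives 38 nM in an assay on isolated protein for inhibition of acyl-CoA:cholesterol acyltransferase (Oryctolagus cuniculus) (on this read-out lower numbers stand for stronger inhibition and higher numbers for weaker inhibition), compound 2 `CCCCc1ccc(NC(=O)Nc2c(C(C)C)cccc2C(C)C)cc1` gives 29 nM, and compound 3 `Cc1ccc(NC(=O)Nc2c(C(C)C)cccc2C(C)C)cc1` gives 250 nM, the highest of the three numbers. Compound 4 `CCCCCCCCCCc1ccc(NC(=O)Nc2c(C(C)C)cccc2C(C)C)cc1` is the unmeasured member: it differs from compound 3 by nonyl in place of hydrogen on a saturated chain carbon bound to an aromatic carbon.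

Among the measured compounds shown here, two measured steps bear directly on this change. Shortening the chain raised the number in both: a 6.6-fold higher number from compound 1 to compound 3 (0.82 log units; beyond the scatter) and an 8.6-fold higher number from compound 2 to compound 3 (0.94 log units; beyond the scatter). The further lengthening between compounds 1 and 2 gave only a 1.3-fold lower number from compound 1 to compound 2 (0.12 log units; within the scatter), so the gain from added chain length appears to flatten once the chain is a few carbons long. Reading these steps in reverse, a longer chain on compound 4 is expected to lower the number clearly, though the extra length beyond butyl is not expected to add much; the estimated step is an 11-fold lower number from compound 3 to compound 4 (1.06 log units; beyond the scatter). Compound 4 is therefore expected to give about 22 nM, within a range from 6 nM to 80 nM.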

Compound 4, half-maximal inhibitory concentration: 13 nM
The estimate for compound 4 lay 1.7-fold (0.23 log units) above the measured number; measured number inside the range.
By their numbers in this assay, from the lowest: compound 4; then compounds 2 and 1 (each within the scatter of the next); then compound 3.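

In this assay, compound 4 shows that the gain from chain length does not end at butyl: there is a 2.2-fold lower number from compound 2 to compound 4 (0.35 log units; beyond the scatter) and a 2.9-fold lower number from compound 1 to compound 4 (0.47 log units; beyond the scatter). This holds even though the step between compound 1 and compound 2 stayed within the scatter. With a 19-fold lower number from compound 3 to compound 4 (1.28 log units; beyond the scatter) as the largest step among these four compounds, the numbers fall as the chain grows from methyl to decyl, except that compound 1 and compound 2 cannot be told apart. No measurement here speaks to why the number falls as the chain grows.

As far as these compounds go, what a chain longer than decyl would do remains open: the number might keep falling, level off or rise. Also open, from the compounds shown here alone, is whether a chain carrying an amine or a carboxylic acid would keep the number this low.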